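The compounds below may be only part of what the source reports. "The series", "measured", "known", "first", "only" and "open" are said of these compounds alone.

Working notes on the series. The shared core of compound 1 `CCC1=C(O)c2c(oc(-c3ccc(CC)cc3)cc2=O)C(CC)(CC)C1=O` carries a 4-ethylphenyl group; in a functional assay on KB cells (Homo sapiens) for antiproliferative activity, read by sulforhodamine B assay, with a stated time of 3 days (on this read-out lower numbers stand for an effect already at smaller amounts and higher numbers for an effect only at larger amounts of compound), compound 1 gives 21.9 uM. Compound 3 `CCC1=C(O)c2c(oc(-c3ccc(C)c(Cl)c3)cc2=O)C(CC)(CC)C1=O` gives 39 uM in this assay, and the step of a 1.8-fold higher number from compound 1 to compound 3 (0.25 log units; within the scatter) leaves the two undivided. Compound 2 `CCC1=C(O)c2c(oc(-c3ccc(SC)cc3)cc2=O)C(CC)(CC)C1=O` reaches only a limit of this assay, > 52.1 uM, recorded as the limit of > 52.1 uM in this assay, at which 1 of the 3 values shown sits.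

Compound 4 `CCC1=C(O)c2c(oc(-c3ccc(C)c(F)c3)cc2=O)C(CC)(CC)C1=O` differs from compound 1 as follows: 3-fluoro-4-methylphenyl in place of 4-ethylphenyl on an aromatic carbon. The step from compound 1 to compound 3, the closest measured parallel with a halogen and methyl in place of ethyl, stayed within the scatter, so no step beyond the scatter is expected in this assay. The expected step is a 1.4-fold higher number from compound 1 to compound 4 (0.14 log units; within the scatter). Compound 4 is estimated at 30 uM, with a range from 12 uM to 70 uM.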

Compound 4, concentration for half-maximal effect: 28.1 uM
The estimate for compound 4 lay 1.1-fold (0.03 log units) above the measured number; the range from low to high includes it.
By their numbers in this assay, from the lowest: compounds 1, 4 and 3 (each within the scatter of the next). At a limit, above all of these: compound 2.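

Fluoro in place of chloro, the smallest change in the series so far, gives a 1.4-fold lower number from compound 3 to compound 4 (0.14 log units; within the scatter), and the change from the 4-ethylphenyl group gives a 1.3-fold higher number from compound 1 to compound 4 (0.11 log units; within the scatter), so in this assay these three aryl groups stay undivided. Measured against the 4-(methylsulfanyl)phenyl group, the new group gives an at least 1.8-fold lower number from compound 2 to compound 4 (0.26 log units; that floor lies within the scatter), so this pair also stays undivided. Compound 2 remains a limit and no true gap can be read from it: the limit of > 52.1 uM in this assay, at which 1 of the 4 values shown sits.

Still open, as far as these compounds go, is whether an amine, a carboxylic acid or a longer chain on this aryl ring would shift the number beyond the scatter.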